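The source may hold more compounds than are shown below. What is called first, only, known or untested is meant among the compounds shown, and "the series" means these compounds.

Of the compounds shown here, three have been measured in a functional assay on microsomes for inhibition, with a stated time of 1 h; on this read-out higher numbers stand for weaker inhibition and lower numbers for stronger inhibition. Compound 3 `CCOC(=O)c1cnn(-c2nc(-c3cccs3)c(C#N)c(=O)n2C)c1N` gives 97 ug/mL, and compound 1 `CCOC(=O)c1cnn(-c2nc(-c3ccco3)c(C#N)c(=O)n2C)c1N` gives 116 ug/mL. Within the data shown here, the single change between them, (furan-2-yl in place of thiophen-2-yl on an aromatic carbon), made a step of a 1.2-fold higher number from compound 3 to compound 1 (0.08 log units; within the scatter). Compound 2 `Cn1c(NN)nc(-c2cccs2)c(C#N)c1=O` rests on a different core; the difference between the core of compound 2 and the core of compound 3 is not broken down here. In this assay compound 2 gives 68 ug/mL, and its distances to compound 3 and to compound 1 both lie within the scatter, so no order among the three is claimed.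

Compound 4 `Cn1c(NN)nc(-c2ccco2)c(C#N)c1=O` has not yet been measured. Its difference from compound 2 is furan-2-yl in place of thiophen-2-yl on an aromatic carbon. Among the measured compounds shown here, this is the same kind of change as the one from compound 3 to compound 1, not the same one: in compound 2 the place is meta to an aminoamino group (2 heavy atoms), whereas in compound 3 it is meta to a large group. A similarly small step is expected, a 1.2-fold higher number from compound 2 to compound 4 (0.07 log units; within the scatter), because the earlier step of a 1.2-fold higher number from compound 3 to compound 1 (0.08 log units; within the scatter) stayed within the scatter. The value of compound 4 in this assay is therefore expected to be 80 ug/mL, with a range from 45 ug/mL to 145 ug/mL. This rests on compound 2 at 68 ug/mL as the starting point and on one prior instance of the change, so the range is kept wide.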

Compound 4, half-maximal inhibitory concentration: 78 ug/mL
Compound 4: the middle estimate sits 1.0-fold (0.01 log units) above what was measured, within the range that was stated.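

In this assay, furan-2-yl in place of thiophen-2-yl on an aromatic carbon gives a 1.1-fold higher number from compound 2 to compound 4 (0.06 log units; within the scatter), so this exchange leaves no readable change on the core of compound 2. Set beside the earlier instance, the exchange carries from one core to the other with no readable difference between the two steps: the same change on two cores in this assay, a 1.2-fold higher number (0.08 log units; within the scatter) from compound 3 to compound 1 and a 1.1-fold higher number (0.06 log units; within the scatter) from compound 2 to compound 4, 1.0-fold (0.02 log units) apart, within the scatter of two such steps. Among these compounds, this shows only that the exchange behaved alike on these two cores, with each step inside the scatter; two instances establish no rule for other cores, do not separate furan-2-yl from thiophen-2-yl in this read-out, and give no explanation for the agreement.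

As far as these compounds go, all four compounds carry a five-membered aromatic ring with 1 hetero atom at this place, so it remains open whether a phenyl ring, an amine or a longer alkyl chain there would give a step beyond the scatter on either core. Also open, from the compounds shown here alone, is what a carboxylic acid in place of the cyano group would do, since that group is common to all four compounds.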